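The compounds below may be only part of what the source reports. "The series", "measured", "known", "first", "only" and "open" are said of these compounds alone.

Measured compounds:
compound 1 `COC(=O)c1ccc(N(Cc2ccc(C3CCCCC3)nc2)C(=O)[C@H]2CCN2S(=O)(=O)c2c(F)c(F)c(F)c(F)c2F)cc1O` with 2000 nM
compound 2 `O=C(NO)c1ccc(N(Cc2ccc(C3CCCCC3)cc2)C(=O)[C@H]2CCN2S(=O)(=O)c2c(F)c(F)c(F)c(F)c2F)cc1` with 5000 nM
compound 3 `CONC(=O)c1ccc(N(Cc2ccc(C3CCCCC3)cn2)C(=O)[C@H]2CCN2S(=O)(=O)c2c(F)c(F)c(F)c(F)c2F)cc1O` with 6700 nM

In a functional assay on MDA-MB-231 cells (Homo sapiens) for antiproliferative activity, with a stated time of 72 h (on this read-out lower numbers stand for an effect already at smaller amounts and higher numbers for an effect only at larger amounts of compound), compound 1 gives 2000 nM, compound 2 gives 5000 nM and compound 3 gives 6700 nM. Compound 3 has the highest of the three numbers. Its nearest neighbour is compound 2, whose number is lower by a gap that lies within the usual scatter, so the two cannot be ranked against each other; compound 1 lies furthest from compound 3, and that gap is beyond the scatter. No pair of these compounds differs in only one place, so no single step between measured compounds is available.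

Compound 4 `O=C([C@H]1CCN1S(=O)(=O)c1c(F)c(F)c(F)c(F)c1F)N(Cc1ccc(C2CCCCC2)cn1)c1ccc2c(=O)[nH]cnc2c1` has not yet been measured in this assay. It is derived from compound 3 by one change: a group of 11 heavy atoms (8 carbon, 2 nitrogen, 1 oxygen; one six-membered aromatic ring of carbon only, one six-membered aromatic ring with 2 hetero atoms) in place of a group of 12 heavy atoms (8 carbon, 1 nitrogen, 3 oxygen; one six-membered aromatic ring of carbon only), on an amide-type nitrogen. Among the measured compounds shown here, no measured pair shows the effect of such a replacement, so the expectation rests on the spread of the three numbers alone. The step of a 1.7-fold lower number from compound 3 to compound 4 (0.22 log units; within the scatter) is expected to be small, towards a somewhat lower number, but not clearly beyond the scatter. Compound 4 is accordingly estimated at 4000 nM, with a range from 1000 nM to 15000 nM.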

Compound 4, half-maximal effective concentration: 3300 nM
Compound 4: the middle estimate sits 1.2-fold (0.08 log units) above what was measured; the range from low to high includes it.
By their numbers in this assay, from the lowest: compounds 1, 4, 2 and 3 (each within the scatter of the next, the first and the last beyond it).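

Among the compounds shown here, on the amide-type nitrogen, this assay now gives a first readable step for this position: placing a group with a six-membered aromatic ring of carbon only and a six-membered aromatic ring with 2 hetero atoms where the 3-hydroxy-4-(methoxycarbamoyl)phenyl group stood gives a 2.0-fold lower number from compound 3 to compound 4 (0.31 log units; beyond the scatter) as a modest change. The position therefore accepts the loss of the whole 3-hydroxy-4-(methoxycarbamoyl)phenyl group without a move towards a higher number, although the gain remains small. Nothing shown accounts for this step.

Because the whole group changes at once, the compounds shown do not separate the part played by the hydroxy group, the methoxycarbamoyl group or the second ring. They also leave open how a carboxylic acid or an amine on the phenyl ring at this place would read out.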